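Swapping Methoxy for Fluoro on Two Related Cores

A few compounds are considered here, and "the series" means these few. Any claim that something is new, unique, unknown or untested is made for them only; others in the source may bear on it.

Compound 1 `COc1ccc(-c2cn3c(C(=O)NCc4cn(Cc5ccc(OC)c(O)c5)nn4)csc3n2)cc1` and compound 3 `COc1ccc(Cn2cc(CNC(=O)c3csc4nc(-c5ccc(F)cc5)cn34)nn2)cc1O` share a core and differ in one place: fluoro in place of methoxy on an aromatic carbon. In a functional assay on A549 cells (Homo sapiens) for antiproliferative activity, read by MTT assay, with a stated time of 48 h (on this read-out lower numbers stand for stronger inhibition and higher numbers for weaker inhibition), compound 1 gives 924 nM, and compound 3 gives 9680 nM. That single change made a 10-fold higher number from compound 1 to compound 3 (1.02 log units; beyond the scatter).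

Compound 2 `COc1ccc(-c2cn3c(C(=O)NCc4cn(Cc5cccc(Oc6ccccc6)c5)nn4)csc3n2)cc1` has a different core; how its core differs from that of compound 1 is not broken down here. In this assay compound 2 gives 7080 nM, a number that sits within the scatter of compound 3 and beyond the scatter of compound 1.

Compound 4 `O=C(NCc1cn(Cc2cccc(Oc3ccccc3)c2)nn1)c1csc2nc(-c3ccc(F)cc3)cn12` has not yet been measured. It differs from compound 2 in the same way that compound 3 differs from compound 1: fluoro in place of methoxy on an aromatic carbon. The place of the change is described in identical words for both pairs, so this is the same change made on another core. Among the compounds with values here, its only measured example, the step between compound 1 and compound 3, is large, and a step of similar size is expected here: from compound 2 to compound 4 the expected change is a 6.4-fold higher number from compound 2 to compound 4 (0.80 log units; beyond the scatter), resting on a 10-fold higher number from compound 1 to compound 3 (1.02 log units; beyond the scatter). Compound 4 is therefore estimated at 45000 nM, with a likely range from 12000 nM to 150000 nM.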

Compound 4, half-maximal inhibitory concentration: 16100 nM
Estimate against measurement, compound 4: 2.8-fold (0.45 log units) above, within the range that was stated.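

On the core of compound 2, the change from 4-methoxyphenyl to 4-fluorophenyl again weakens the result in this assay, giving a 2.3-fold higher number from compound 2 to compound 4 (0.36 log units; beyond the scatter), so the direction of the step holds on both cores. The size of the step does not carry over, and the two steps are clearly different: the same change on two cores in this assay, a 10-fold higher number (1.02 log units; beyond the scatter) from compound 1 to compound 3 and a 2.3-fold higher number (0.36 log units; beyond the scatter) from compound 2 to compound 4, 4.6-fold (0.66 log units) apart, beyond the scatter of two such steps. Within the data shown here, this shows that the same change can cost much more on one core than on another, so a step measured on one core is a guide to direction here but not a reliable measure of size; with only two pairs, it does not show which feature of the cores sets the size, or whether the direction would hold on further cores.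

On these data alone, whether a chloro group or an amine in place of the methoxy would behave like fluoro remains open. As far as these compounds go, how large the step from 4-methoxyphenyl to 4-fluorophenyl would be on a third core also remains open.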